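A Methoxypyridinyl Amine in Place of a Chloro Ester Aryl

This account rests on a few compounds, and the source may have more. Where it says the series, first, only, none or still open, it means among the compounds named here.

In a functional assay on A549 cells (Homo sapiens) for cytotoxicity, read by sulforhodamine B assay, with a stated time of 72 h (a lower number here means a stronger inhibitor, a higher number a weaker inhibitor), compound 3 `CCS(=O)(=O)Nc1cc(-c2ccc3ncnc(Nc4ccc(Cl)c(C(=O)OC)c4)c3c2)cnc1OC` gives 2130 nM, the lowest number of the three measured analogues. Compound 1 `CCS(=O)(=O)Nc1cc(-c2ccc3ncnc(Nc4ccc(F)cc4F)c3c2)cnc1OC` gives 4710 nM and compound 2 `CCS(=O)(=O)Nc1cc(-c2ccc3ncnc(Nc4ccc(OC)cc4)c3c2)cnc1OC` gives 3580 nM. The steps were a 2.2-fold lower number from compound 1 to compound 3 (0.34 log units; beyond the scatter) and a 1.7-fold lower number from compound 2 to compound 3 (0.23 log units; within the scatter), while a 1.3-fold lower number from compound 1 to compound 2 (0.12 log units; within the scatter). Compound 4 `CCS(=O)(=O)Nc1cc(-c2ccc3ncnc(Nc4ccc(OC)nc4)c3c2)cnc1OC` differs from compound 3 by 6-methoxypyridin-3-yl in place of 4-chloro-3-(methoxycarbonyl)phenyl on a nitrogen on an aromatic ring. Among the measured compounds shown here, the step that bears most on this is the one from compound 2 to compound 3, since compound 2 also carries a methoxy group on the aryl amine, and that step stayed within the scatter. Compound 4 is therefore expected to give about 3500 nM in this assay, in a range of 1500 nM to 8000 nM. This estimate means a 1.6-fold higher number from compound 3 to compound 4 (0.22 log units; within the scatter), a rise expected to be small.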

Compound 4, half-maximal inhibitory concentration: 5560 nM
Compound 4: the middle estimate sits 1.6-fold (0.20 log units) below what was measured; the measured number falls inside the stated range.
By their numbers in this assay, from the lowest: compounds 3, 2, 1 and 4 (each within the scatter of the next, the first and the last beyond it).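

On this nitrogen on an aromatic ring, 6-methoxypyridin-3-yl in place of 4-chloro-3-(methoxycarbonyl)phenyl gives a 2.6-fold higher number from compound 3 to compound 4 (0.42 log units; beyond the scatter) and so shows a second replacement of that group moving the number beyond the scatter. Against the other two aryl groups, the new group gives a 1.6-fold higher number from compound 2 to compound 4 (0.19 log units; within the scatter) and a 1.2-fold higher number from compound 1 to compound 4 (0.07 log units; within the scatter) and so cannot be told apart from either. No measured evidence accounts for these steps.

The compounds shown leave open how a 4-chlorophenyl group or the matching carboxylic acid would compare, so the separate parts of the chlorine and the methyl ester remain unresolved.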